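This account rests on a few compounds, and the source may have more. Where it says the series, first, only, none or still open, it means among the compounds named here.

Compounds measured in a functional assay on MDA-MB-231 cells (Homo sapiens) for antiproliferative activity, read by MTT assay, with a stated time of 72 h; a lower number here means a stronger inhibitor, a higher number a weaker inhibitor:

Compound 1 `O=C(Nc1ccc(-c2noc(-c3cccc(NS(=O)(=O)c4ccc(C(F)(F)F)cc4)c3)n2)c(Cl)c1)c1cccnc1` gives > 10000 nM, which is a limit of the assay.
Compound 2 `CC(=O)Nc1ccc(S(=O)(=O)Nc2cccc(-c3nc(-c4ccc(NC(=O)c5cccnc5)c(C(F)(F)F)c4)no3)c2)cc1` gives > 10000 nM, which is a limit of the assay.
Compound 3 `O=C(Nc1ccccc1)Nc1cccc(-c2nc(-c3ccc(NC(=O)c4cccnc4)cc3Cl)no2)c1` gives > 10000 nM, which is a limit of the assay.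

Compound 3 therefore stands at the edge of what this assay can report, and it does not stand alone there: the limit of > 10000 nM in this assay, at which 3 of the 3 values shown sit, describes the whole set, so none of the three compounds has a number that could be ranked against another. Among the compounds with values here, no single-point step between measured compounds exists, and nothing in these three results shows which part of the shared core would move the read-out.

Compound 4 `C#Cc1ccc(NC(=O)Nc2cccc(-c3nc(-c4ccc(NC(=O)c5cccnc5)cc4Cl)no3)c2)cc1` is the next compound. It differs from compound 3 by ethynyl in place of hydrogen on an aromatic carbon, so that the phenylcarbamoyl end of the urea becomes a (4-ethynylphenyl)carbamoyl group, with the rest of the molecule untouched. With compound 3 sitting at a limit, the step to compound 4 cannot be measured as a full number, and the author expects it, an at least 1.1-fold lower number from compound 3 to compound 4 (0.04 log units; that floor lies within the scatter), to fall within the scatter or, at most, to bring compound 4 just inside the range the assay can report. Compound 4 is therefore estimated at 9000 nM, with a range from 2000 nM to 30000 nM.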

Compound 4, half-maximal inhibitory concentration: > 10000 nM
Compound 4 was reported as a limit; the forecaster's own chance of this, stated with the estimate: 65%; middle value at least 1.1-fold (0.04 log units) away from the limit.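

Compound 4 gives > 10000 nM, which is a limit of the assay. Compound 3 also sits at a limit, so no step can be read between compound 3 and compound 4. The compounds shown leave open whether any change to the shared core would bring a value inside the range of this assay, because the whole set remains at one edge: the limit of > 10000 nM in this assay, at which 4 of the 4 values shown sit.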